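The source may report more compounds than this note shows. Statements on the series, on what has been measured and on what is new or still open speak of the compounds shown alone.

Compound 1 `CN1C(=O)N(C)C2C1NC(=S)N2/N=C/C=C/c1ccccc1` and compound 2 `CN1C(=O)N(C)C2C1NC(=S)N2/N=C/C=C/c1ccccc1[N+](=O)[O-]` share one core, and in a functional assay on A549 cells (Homo sapiens) for inhibition, read by MTT assay, with a stated time of 72 h (on this read-out higher numbers stand for weaker inhibition and lower numbers for stronger inhibition), compound 1 gives 45700 nM while compound 2 gives 2720 nM. The change between them, (nitro in place of hydrogen on an aromatic carbon), produced a 17-fold lower number from compound 1 to compound 2 (1.23 log units; beyond the scatter). Compound 3 `CCN1C(=O)N(CC)C2C1NC(=O)N2/N=C/C=C/c1ccccc1` has a different core; the difference between the two cores is not broken down here. In this assay compound 3 gives 44300 nM, which sits within the scatter of the number for compound 1. Compound 4 `CCN1C(=O)N(CC)C2C1NC(=O)N2/N=C/C=C/c1ccccc1[N+](=O)[O-]` is compound 3 carrying the same change, (nitro in place of hydrogen on an aromatic carbon), which has so far been seen once. Because compound 3 gives 44300 nM in this assay and compound 1 gives 45700 nM there, a step of similar size is expected from compound 3 to compound 4, a 16-fold lower number from compound 3 to compound 4 (1.22 log units; beyond the scatter), beside the step from compound 1 to compound 2. For compound 4 the estimate in this assay is 2700 nM, with a range from 1000 nM to 8000 nM.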

Compound 4, half-maximal inhibitory concentration: > 100000 nM
Compound 4 ended at the assay's limit; the forecaster's own chance of this, stated with the estimate: 3%; middle value at least 37-fold (1.56 log units) away from the limit.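

In this assay compound 4 gives > 100000 nM, which is a limit of the assay and not a number. The change that lowered the number on the core of compound 1 went the other way on the core of compound 3, giving an at least 2.2-fold higher number from compound 3 to compound 4 (0.35 log units; beyond the scatter), so in this series its effect did not carry from one core to the other: the same change on two cores in this assay, a 17-fold lower number (1.23 log units; beyond the scatter) from compound 1 to compound 2 and an at least 2.2-fold higher number (0.35 log units; beyond the scatter) from compound 3 to compound 4, at least 37-fold (1.57 log units) apart, beyond the scatter of two such steps. With one pair on each core and one value at a limit, this does not show how far compound 4 truly lies from compound 3, nor which feature of the two cores sets the steps apart.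

The compounds shown leave open whether an amine in place of the nitro group would also separate the two cores. They also leave open how a longer chain on the core of compound 3 would behave.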